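Trimming the amine tail of compound 1

The source may report more compounds than this note shows. Statements on the series, on what has been measured and on what is new or still open speak of the compounds shown alone.

Compound 1 `CC1(C)[C@H]2CC[C@]1(C)[C@H](OC(=O)CCCCN1CCCCC1)C2` gives 101000 nM in an ADME assay on HEK-293T cells (Homo sapiens) for cytotoxicity, read by MTT assay, with a stated time of 48 h; a higher number here means that more compound is tolerated, a lower number that less compound is tolerated. Among the three measured values it is the lowest: compound 2 `CCN1CCN(CC(=O)O[C@@H]2C[C@@H]3CC[C@@]2(C)C3(C)C)CC1` gives 130000 nM, which lies within the scatter of compound 1, while compound 3 `CC1(C)[C@H]2CC[C@]1(C)[C@H](OC(=O)CN1CCN(CCN)CC1)C2` gives 247000 nM, beyond it. For the measured compounds named here, the one step between single-change neighbours, a 1.9-fold higher number from compound 2 to compound 3 (0.28 log units; within the scatter), concerns the amine end of the ester chain and stays within the scatter. Compound 4 `CN(C)CCCC(=O)O[C@@H]1C[C@@H]2CC[C@@]1(C)C2(C)C` differs from compound 1 by dimethylamino in place of (piperidin-1-yl)methyl on a saturated chain carbon, three bonds along the chain from a carbonyl carbon. Going by the values given here, this change also sits at the amine end, and the single comparable step offers no ground to expect more than scatter in this assay, in either direction. Compound 4 is therefore expected to give about 110000 nM, with a range from 50000 nM to 250000 nM, meaning a step of a 1.1-fold higher number from compound 1 to compound 4 (0.04 log units; within the scatter).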

Compound 4, half-maximal cytotoxic concentration: 101000 nM
The estimate for compound 4 lay 1.1-fold (0.04 log units) above the measured number; the range from low to high includes it.
By their numbers in this assay, from the lowest: compounds 1, 4, 2 and 3 (each within the scatter of the next, the first and the last beyond it).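

In this assay, dimethylamino in place of (piperidin-1-yl)methyl on a saturated chain carbon, three bonds along the chain from a carbonyl carbon, leaves no change at the digits printed from compound 1 to compound 4 (within the scatter) as the whole outcome. The earlier step concerned a different change, whereas this one shows that at this position the ring-bearing group can give way to a smaller group with no ring without a reading beyond the scatter. No evidence is available to explain this result.

From the compounds shown here alone, whether a primary amine, a carboxylic acid or a longer chain at this position would also stay within the scatter remains open.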